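From 4-chlorophenyl to 2-methoxyphenyl on the carbonyl

This account rests on a few compounds, and the source may have more. Where it says the series, first, only, none or still open, it means among the compounds named here.

Two compounds with a shared core have numbers in a functional assay on MOLT-4 cells (Homo sapiens) for antiproliferative activity, read by cell counting, with a stated time of 2 days (on this read-out lower numbers stand for stronger inhibition and higher numbers for weaker inhibition), so far. Compound 1 (`COc1ccc(Nc2nc(N)c(C(=O)c3ccc(Cl)cc3)s2)cc1`) gives 13 nM as the lower of the two, and compound 2 (`COc1ccc(Nc2nc(N)c(C(=O)c3ccc([N+](=O)[O-])cc3)s2)cc1`) gives 29 nM as the higher. Going by the values given here, the only measured step is a 2.2-fold higher number from compound 1 to compound 2 (0.35 log units; beyond the scatter) with nitro in place of chloro on an aromatic carbon, a modest change beyond the scatter.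

Compound 3 (`COc1ccc(Nc2nc(N)c(C(=O)c3ccccc3OC)s2)cc1`) has not yet been measured. It differs from compound 1 as follows: 2-methoxyphenyl in place of 4-chlorophenyl on a carbonyl carbon with 2-methoxyphenyl in place of 4-chlorophenyl on a carbonyl carbon. The step to compound 2 bears on this only loosely, since it alters a single substituent and leaves the rest of that aromatic group as it stands. Among the compounds with values here, no measured compound carries a methoxy group on this side, so the direction rests on thin evidence. Compound 1 holds the lower number, and a somewhat larger step than the measured one is expected. The estimated step is a 3.8-fold higher number from compound 1 to compound 3 (0.59 log units; beyond the scatter) toward a higher number. In this assay compound 3 is estimated at 50 nM with 12 nM to 250 nM as the expected range.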

Compound 3, half-maximal inhibitory concentration: 18 nM
Compound 3: middle estimate off by 2.8-fold (0.44 log units), on the high side; measured number inside the range.
By their numbers in this assay, from the lowest: compounds 1, 3 and 2 (each within the scatter of the next, the first and the last beyond it).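

In this assay the exchange of 4-chlorophenyl for 2-methoxyphenyl on the carbonyl carbon amounts to a 1.4-fold higher number from compound 1 to compound 3 (0.14 log units; within the scatter) and so leaves compound 1 and compound 3 indistinguishable on this read-out. The earlier pair showed only one substituent being exchanged on an otherwise unaltered aromatic group, whereas here both the substituent and its place on the ring differ, and the result still shows no difference beyond the scatter. The position therefore accommodates a more thorough change to this aromatic group than the earlier pair had tested, but no measurement available for these groups explains this outcome.

Since the substituent and its place differ together in this step, the two compounds cannot show what each contributes alone, and 4-methoxyphenyl would be the group needed to separate them. On these data alone, it also remains open how this assay would read with a carboxylic acid or a dimethylamino group on the aromatic ring, or with cyclohexyl replacing that ring on the carbonyl carbon.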